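The source may hold more compounds than are shown below. What is called first, only, known or untested is meant among the compounds shown, and "the series" means these compounds.

For the measured compounds named here, compound 2 `COc1cc2ncnc(-n3nc(-c4ccccc4)nc3N)c2cc1OC` has the lowest number of the two measured so far in an assay on MCF7 cells for inhibition of Serine-protein kinase ATM (Homo sapiens), read by immunofluorescence, with a stated time of 1 h; a lower number here means a stronger inhibitor, a higher number a weaker inhibitor: compound 2 gives 2000 nM. Going by the values given here, its nearest neighbour is compound 1 `COc1cc2ncnc(-n3nc(-c4cccnc4)nc3N)c2cc1OC`, which in this assay gives 15000 nM; the one step between them, a 7.5-fold lower number from compound 1 to compound 2 (0.88 log units; beyond the scatter), comes from phenyl in place of pyridin-3-yl on an aromatic carbon. Compound 3 `COc1cc2ncnc(-n3nc(-c4ccc(Cl)cc4)nc3N)c2cc1OC` is the next compound and differs from compound 2 by chloro in place of hydrogen on an aromatic carbon. Among the compounds with values here, no measured step bears directly on this change; the single step from compound 1 to compound 2 concerns the ring itself, not a substituent on it, so it gives no guide to the size or direction of the effect of a chloro group. The expectation for compound 3 is therefore a step of a 1.3-fold lower number from compound 2 to compound 3 (0.12 log units; within the scatter) in this assay, which is within the usual scatter. Compound 3 is estimated at 1500 nM, with a range from 500 nM to 5000 nM.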

Compound 3, half-maximal inhibitory concentration in the Serine-protein kinase ATM assay: > 40000 nM
Compound 3: no number, only a limit; the forecaster's own chance of this, stated with the estimate: 5%; middle value at least 26-fold (1.42 log units) from the limit.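

For the compounds shown here, the place para to a large group on the phenyl ring, bare in the earlier compounds, turns out to be highly sensitive to substitution: in the Serine-protein kinase ATM assay, chloro in place of hydrogen gives an at least 20-fold higher number from compound 2 to compound 3 (1.30 log units; beyond the scatter), while in a physicochemical assay for solubility, in phosphate buffer, with a stated time of 18 h, at pH 7.4 (on this read-out lower numbers stand for lower solubility and higher numbers for higher solubility), the same change gives no change at the digits printed from compound 2 to compound 3 (within the scatter). In the physicochemical assay compound 2 gives 1000 nM and compound 3 gives 1000 nM. In the Serine-protein kinase ATM assay, 4-chlorophenyl in place of pyridin-3-yl also gives an at least 2.6-fold higher number from compound 1 to compound 3 (0.42 log units; beyond the scatter), so this change leaves the inhibitor weaker than the pyridine compound. In the Serine-protein kinase ATM assay compound 3 gives > 40000 nM, which is a limit of the assay and not a number: the limit of > 40000 nM in the Serine-protein kinase ATM assay, at which 1 of the 3 values shown sits.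

From the compounds shown here alone, the true size of both steps in the Serine-protein kinase ATM assay therefore stays open. The compounds shown also cannot tell whether fluoro, methoxy or an amine at this place would behave as chloro does, or whether chloro elsewhere on the phenyl ring would give the same result.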